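A few compounds are considered here, and "the series" means these few. Any claim that something is new, unique, unknown or untested is made for them only; others in the source may bear on it.

Compound 1 `CC(C)N(Cc1cccc(OCCCCCC(=O)O)c1)C(=O)c1ccc(-c2ccsc2)cc1`: in an ADME assay on Raji cells (Homo sapiens) for cytotoxicity, read by CellTiter-Glo and resazurin assay, with a stated time of 72 h (on this read-out higher numbers stand for an effect only at larger amounts of compound and lower numbers for an effect already at smaller amounts), compound 1 gives a limit, > 26000 nM.
Compound 2 `CC(C)N(Cc1cccc(OCCCCCC(=O)O)c1)C(=O)c1ccc(-c2cccc(OCc3ccccc3)c2)cc1`: in this assay compound 2 gives a limit, > 26000 nM.

Among the compounds with values here, compound 2 stands at the limit of this assay, and compound 1 stands there too; the limit of > 26000 nM in this assay, at which 2 of the 2 values shown sit, covers both values shown, so no step between measured compounds is known. Compound 3 `COc1cccc(-c2ccc(C(=O)N(Cc3cccc(OCCCCCC(=O)O)c3)C(C)C)cc2)c1` differs from compound 2 in hydrogen in place of phenyl on a saturated chain carbon bound to an oxygen on an aromatic ring, which read one bond further out is benzyloxy to methoxy. Within the data shown here, with no measured step to lean on, the step that the limit leaves unreadable from compound 2 to compound 3 is expected to be none beyond the scatter. Compound 3 is therefore estimated at 30000 nM, within 10000 nM to 100000 nM, and most likely reported again only as a limit.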

Compound 3, half-maximal effective concentration: > 20900 nM
Compound 3 was reported as a limit; the forecaster's own chance of this, stated with the estimate: 80%; the middle value lies beyond the limit too.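

In this assay compound 3, like compound 1 and compound 2, gives only a limit, so no step among these compounds can be read. The compounds shown leave open at what concentration any of them would reach a half-maximal effect.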